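The source may report more compounds than this note shows. Statements on the series, on what has been measured and on what is new or still open speak of the compounds shown alone.

Of the compounds shown here, two have so far been measured in a functional assay on striatum for inhibition of sodium-dependent dopamine transporter (Rattus norvegicus); a higher number here means a weaker inhibitor, a lower number a stronger inhibitor. Compound 1 `CN[C@@H]1CC[C@@H](c2ccc(Cl)cc2Cl)c2ccccc21` gives 6100 nM in this assay, the lower of the two numbers. Compound 2 `CCCCOc1ccc([C@@H]2CC[C@@H](NC)c3ccccc32)cc1` gives 6800 nM in this assay, and the two values lie within the scatter of each other, so neither can be called the stronger inhibitor.

Compound 3 `CN[C@H]1CC[C@@H](c2ccc(Cl)cc2Cl)c2ccccc21` is the next compound to be tested. Compared with compound 1, (the two compounds have the same atoms and bonds and differ only in configuration as drawn: 1 of 2 stereo elements differ; a stereocentre at a saturated ring carbon is drawn R in compound 1 and S in compound 3). Among the measured compounds shown here, no measured pair in this set shows what such a change in configuration does here, so the size of the step from compound 1 to compound 3 is uncertain. A change no larger than the scatter, or a modest shift in either direction, seems plausible. For compound 3 the expected value in this assay is 4000 nM, with a range from 1000 nM to 15000 nM. This estimate means a step of a 1.5-fold lower number from compound 1 to compound 3 (0.18 log units; within the scatter), judged from compound 1 at 6100 nM.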

Compound 3, half-maximal inhibitory concentration: 1700 nM
For compound 3 the middle estimate is 2.4-fold (0.37 log units) above the measured one; the range from low to high includes it.
By their numbers in this assay, from the lowest: compound 3; then compounds 1 and 2 (each within the scatter of the next).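

Configuration at this saturated ring carbon clearly matters in this assay: with the atoms and bonds left unchanged, drawing the stereocentre S rather than R gives a 3.6-fold lower number from compound 1 to compound 3 (0.55 log units; beyond the scatter). Among the compounds shown here, until now, no measured pair had isolated a single change, so the effect of configuration could not be read at all. The step can be assigned to this stereocentre alone, because nothing else separates the two structures: the fact that compounds 1 and 3 differ only in the configuration as drawn

The compounds shown leave open whether the same inversion would move compound 2 in the same direction, and what changing the second stereocentre would do. They also leave open how a dimethylamino group in place of the methylamino group would behave in either configuration.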